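The source may hold more compounds than are shown below. What is called first, only, known or untested is meant among the compounds shown, and "the series" means these compounds.

Compound 1, `NC(=S)N/N=C1/C(=O)N(CN2CCN(c3ccnc4cc(C(F)(F)F)ccc34)CC2)c2cc(Cl)ccc21`, and compound 2, `NC(=S)N/N=C1/C(=O)N(CN2CCN(c3ccnc4cc(C(F)(F)F)ccc34)CC2)c2cc(Br)ccc21`, share one core; compound 3, `NC(=S)N/N=C1\C(=O)Nc2cccc(Cl)c21`, rests on another, and the difference between the two cores is not broken down here. In an ADME assay on 184B5 cells (Homo sapiens) for cytotoxicity, read by sulforhodamine B assay, with a stated time of 48 h (a higher number here means a weaker inhibitor of growth, a lower number a stronger inhibitor of growth), compound 1 gives 20100 nM, and compound 2 gives 21400 nM; the step between them is a 1.1-fold higher number from compound 1 to compound 2 (0.03 log units; within the scatter), made by bromo in place of chloro on an aromatic carbon. Compound 3 gives 25900 nM in this assay, within the scatter of both. Compound 4, `NC(=S)N/N=C1\C(=O)Nc2cccc(Br)c21`, differs from compound 3 by bromo in place of chloro on an aromatic carbon, the same kind of change as before, though here the place is ortho to a fused ring and meta to a fused ring rather than meta and para. Because the earlier step of a 1.1-fold higher number from compound 1 to compound 2 (0.03 log units; within the scatter) lay within the scatter, compound 4 is expected to show a step of about a 1.1-fold higher number from compound 3 to compound 4 (0.03 log units; within the scatter) in this assay. Compound 4 is therefore estimated at 27500 nM, between 14000 nM and 55000 nM.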

Compound 4, concentration for 50% growth inhibition: 22600 nM
Compound 4: the middle estimate sits 1.2-fold (0.09 log units) above what was measured; low and high end bracket the measured number.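

In this assay, bromo in place of chloro on an aromatic carbon gives a 1.1-fold lower number from compound 3 to compound 4 (0.06 log units; within the scatter). Set beside the earlier step, the change carries from one core to the other as a step within the scatter on both: the same change on two cores in this assay, a 1.1-fold higher number (0.03 log units; within the scatter) from compound 1 to compound 2 and a 1.1-fold lower number (0.06 log units; within the scatter) from compound 3 to compound 4, 1.2-fold (0.09 log units) apart, within the scatter of two such steps. This shows that the swap left the number in this assay essentially unchanged on these two pairs, at two different places; it does not show a direction for the change, nor that it would stay this small on a third core.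

The compounds shown leave open whether an amine, a methoxy group or a carboxylic acid at these places would move the number beyond the scatter. They also leave open how the swap reads in other cells.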